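From diethylamino to piperidin-1-yl on a shared core

The compounds below may be only part of what the source reports. "The series", "measured", "known", "first", "only" and "open" are said of these compounds alone.

Measured so far in an ADME assay on L6 cells (Rattus norvegicus) for cytotoxicity, with a stated time of 72 h (on this read-out higher numbers stand for weaker inhibition and lower numbers for stronger inhibition), for three compounds:
Compound 1 `CC(C)(C)C(=O)OC1CC2(N3CCCC3)CC(c3ccccc3)C1C(c1ccccc1)C2` gives 7620 nM
Compound 2 `O=C(/C=C/c1ccccc1)OC1CC2(N3CCCC3)CC(c3ccccc3)C1C(c1ccccc1)C2` gives 3500 nM
Compound 3 `CCN(CC)CC(=O)OC1CC2(N3CCCC3)CC(c3ccccc3)C1C(c1ccccc1)C2` gives 49000 nM

Compound 3 has the highest number of the three, which here means the weakest inhibition. The next compound, compound 4 `O=C(CN1CCCCC1)OC1CC2(N3CCCC3)CC(c3ccccc3)C1C(c1ccccc1)C2`, differs from it in one place, with piperidin-1-yl in place of diethylamino on a saturated chain carbon bound to a carbonyl carbon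

The measured steps that bring in (diethylamino)methyl are a 6.4-fold higher number from compound 1 to compound 3 (0.81 log units; beyond the scatter) and a 14-fold higher number from compound 2 to compound 3 (1.15 log units; beyond the scatter) and both go upward. Each replaces a group on the carbonyl carbon with that amino-bearing chain. Among the compounds with values here, compound 4 keeps a chain of this kind, as (piperidin-1-yl)methyl, and no measured step swaps diethylamino for piperidin-1-yl. No step beyond the scatter is therefore expected in this assay and the estimate means a 1.4-fold lower number from compound 3 to compound 4 (0.15 log units; within the scatter) as the expected change.

For compound 4 the expected value is 35000 nM with an estimated range from 14000 nM to 90000 nM (an expectation, not a measurement).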

Compound 4, half-maximal inhibitory concentration: 14200 nM
The estimate for compound 4 lay 2.5-fold (0.39 log units) above the measured number, within the range that was stated.
By their numbers in this assay, from the lowest: compound 2; then compounds 1 and 4 (each within the scatter of the next); then compound 3.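

In this assay, piperidin-1-yl in place of diethylamino on the same chain gives a 3.5-fold lower number from compound 3 to compound 4 (0.54 log units; beyond the scatter), so changing the amine alone moves the number, even though the link to the carbonyl stays the same. Amino-bearing chains therefore do not all behave alike at this position: replacing tert-butyl with (piperidin-1-yl)methyl gives a 1.9-fold higher number from compound 1 to compound 4 (0.27 log units; within the scatter), whereas replacing 2-phenylethenyl with the same chain gives a 4.1-fold higher number from compound 2 to compound 4 (0.61 log units; beyond the scatter) and so still leaves a clear gap. No measurement shown here explains why the two amines differ.

As far as these compounds go, only two amines appear on this chain, so it remains open whether the ring itself matters or whether another ring amine, such as morpholin-4-yl, would behave like piperidin-1-yl. From the compounds shown here alone, the effect of a longer chain carrying piperidin-1-yl also remains open.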